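Amide in place of nitrile at the chain end

A few compounds are considered here, and "the series" means these few. Any claim that something is new, unique, unknown or untested is made for them only; others in the source may bear on it.

Compound 3 `N#CCCCCCOc1cc(-c2ccccc2)cc(-c2ccccc2)n1` gives 700 nM in an assay on cell membranes from spleen (Cavia porcellus) for binding affinity to leukotriene B4 receptor 1 (Homo sapiens) (on this read-out higher numbers stand for weaker inhibition and lower numbers for stronger inhibition), the highest number of the three measured and so the weakest binder among them. Compound 1 `CC(CCCCOc1cc(-c2ccccc2)cc(-c2ccccc2)n1)C(=O)O` gives 4 nM and compound 2 `CC(C)(CCCCCCOc1cc(-c2ccccc2)cc(-c2ccccc2)n1)C(=O)O` gives 22 nM. The step of a 180-fold higher number from compound 1 to compound 3 (2.24 log units; beyond the scatter) and the step of a 32-fold higher number from compound 2 to compound 3 (1.50 log units; beyond the scatter) both show that replacing a terminal carboxylic acid by a nitrile raises the number sharply. Compound 4 `NC(=O)CCCCCOc1cc(-c2ccccc2)cc(-c2ccccc2)n1` carries carbamoyl in place of cyano on a saturated chain carbon, five bonds along the chain from an oxygen on an aromatic ring. Among the compounds with values here, no measured pair exchanges nitrile for carbamoyl, so the two acid steps only indicate that the group at the chain end can move the number considerably; the carbamoyl adds one hydrogen-bond donor that the nitrile lacks. For compound 4 in this assay a modest step toward a lower number is expected, a 1.8-fold lower number from compound 3 to compound 4 (0.24 log units; within the scatter). Compound 4 is estimated at 400 nM, within 120 nM to 1500 nM.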

Compound 4, half-maximal inhibitory concentration: 160 nM
Compound 4: middle estimate off by 2.5-fold (0.40 log units), on the high side; the range from low to high includes it.
By their numbers in this assay, from the lowest: compound 1; then compound 2; then compound 4; then compound 3.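

Carbamoyl and cyano at this chain end are not interchangeable: in this assay the direct exchange gives a 4.4-fold lower number from compound 3 to compound 4 (0.64 log units; beyond the scatter) and so lies beyond the usual scatter. Carbamoyl recovers only part of the ground held by the acids, with a 7.3-fold higher number from compound 2 to compound 4 (0.86 log units; beyond the scatter) and a 40-fold higher number from compound 1 to compound 4 (1.60 log units; beyond the scatter) still separating the amide from them. No supporting measurement bears on the source of these steps.

Open, from the compounds shown here alone, is whether the amide hydrogen carries the gain, which an N-methyl amide or a primary amine at the chain end would test. Also open, going by these compounds, is how a carboxylic acid would read on the chain of compound 4.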